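Furan for Thiophene on a Nucleoside Core

The source may hold more compounds than are shown below. What is called first, only, known or untested is meant among the compounds shown, and "the series" means these compounds.

Compound 1, `Nc1nc(N)c2c(-c3ccsc3)cn([C@@H]3O[C@H](CO)[C@@H](O)[C@H]3O)c2n1`, in a functional assay on HeLa S3 cells (Homo sapiens) for antiproliferative activity, read by XTT assay, with a stated time of 72 h (a higher number here means a weaker inhibitor, a lower number a stronger inhibitor), gives > 20000 nM.
Compound 2, `COc1ncnc2c1c(I)cn2[C@@H]1O[C@H](CO)[C@@H](O)[C@H]1O`, in this assay gives 14300 nM.

The value for compound 1 is a limit of this assay and not a number, as noted by the limit of > 20000 nM in this assay, at which 1 of the 2 values shown sits. Going by the values given here, compound 2 is the only member of this pair with a measured number, and no single-point step connects the two measured compounds. Compound 3, `Nc1nc(N)c2c(-c3ccoc3)cn([C@@H]3O[C@H](CO)[C@@H](O)[C@H]3O)c2n1`, keeps the core of compound 1 and differs by furan-3-yl in place of thiophen-3-yl on an aromatic carbon. Among the compounds with values here, with no measured step in hand, the change from compound 1 to compound 3 is expected to move this assay little, if at all, beyond the usual scatter, and the step that the limit leaves unreadable from compound 1 to compound 3 is estimated to be small. Compound 3 is therefore expected to give about 25000 nM, within a range of 8000 nM to 80000 nM, with a good chance that only a limit is reported.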

Compound 3, half-maximal inhibitory concentration: > 20000 nM
Compound 3: only a limit was reported; the forecaster's own chance of this, stated with the estimate: 70%; the middle value does not contradict the limit.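

Compound 3 gives > 20000 nM in this assay as a limit and not a number. Going by these compounds alone, compound 1 also stands at a limit, and no step from compound 1 to compound 3 can be read. The compounds shown leave open how furan-3-yl and thiophen-3-yl compare in this assay on the shared core.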